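Side-chain exchange on the nitrophenyl compound

The compounds below may be only part of what the source reports. "The series", "measured", "known", "first", "only" and "open" are said of these compounds alone.

Values in a functional assay on A549 cells (Homo sapiens) for cytotoxicity, read by MTT assay, with stated times of 48 h and 4 h; a lower number here means a stronger inhibitor, a higher number a weaker inhibitor:
- Compound 1 `COc1ccc(/C=C/c2nc(NCCN(C(C)C)C(C)C)c3ccccc3n2)cc1OC`: 38800 nM
- Compound 2 `COc1ccc(/C=C/c2nc(NCCCCN)c3ccccc3n2)cc1OC`: > 100000 nM (a limit)
- Compound 3 `CC(C)N(CCNc1nc(/C=C/c2ccc([N+](=O)[O-])cc2)nc2ccccc12)C(C)C`: > 100000 nM (a limit)

Compound 3 gives no number, and it sits at the limit of > 100000 nM in this assay, at which 2 of the 3 values shown sit. Compound 4 `NCCCCNc1nc(/C=C/c2ccc([N+](=O)[O-])cc2)nc2ccccc12` differs from it only in the side chain: 2-aminoethyl in place of diisopropylamino on a saturated chain carbon, two bonds along the chain from a nitrogen on an aromatic ring. This places 2-aminoethyl in place of diisopropylamino on a saturated chain carbon, two bonds along the chain from a nitrogen on an aromatic ring.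

The same exchange has been measured once, on the 3,4-dimethoxyphenyl compound, where it gave an at least 2.5-fold higher number from compound 1 to compound 2 (0.41 log units; beyond the scatter). The other measured step, which brings in the 4-nitrophenyl group, gave an at least 2.5-fold higher number from compound 1 to compound 3 (0.41 log units; beyond the scatter). On these data alone, both steps are bounded by the limit, so their true sizes are unknown, but both run towards weaker inhibition. Compound 4 carries both changes, so no gain in this assay is expected, and any further rise should be hidden by the limit. The expected change is a step that the limit leaves unreadable from compound 3 to compound 4, small or unreadable. Compound 4 is estimated at 120000 nM, within an expected range of 40000 nM to 300000 nM.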

Compound 4, half-maximal inhibitory concentration: 5480 nM
Compound 4: middle estimate off by 22-fold (1.34 log units), on the high side, outside the stated range (below it).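

In this assay, putting 2-aminoethyl in place of diisopropylamino on a saturated chain carbon, two bonds along the chain from a nitrogen on an aromatic ring, gives an at least 18-fold lower number from compound 3 to compound 4 (1.26 log units; beyond the scatter). Compound 3 reads > 100000 nM, which is a limit. The direction of this exchange is therefore not fixed at this position: it depends on whether the compound carries 4-nitrophenyl or 3,4-dimethoxyphenyl, so the two changes cannot be treated as independent in this pair of cores: the same change on two cores in this assay, an at least 2.5-fold higher number (0.41 log units; beyond the scatter) from compound 1 to compound 2 and an at least 18-fold lower number (1.26 log units; beyond the scatter) from compound 3 to compound 4, at least 47-fold (1.67 log units) apart, beyond the scatter of two such steps.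

On these data alone, it stays open whether the primary amine or the chain length accounts for the step; a 4-(diisopropylamino)butyl chain on the 4-nitrophenyl compound would separate the two. Also open, as far as these compounds go, is whether the same direction holds with another group in place of 4-nitrophenyl, such as 4-chlorophenyl.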